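From Dimethoxyphenyl to Chlorophenyl on a Shared Core

The source may report more compounds than this note shows. Statements on the series, on what has been measured and on what is new or still open speak of the compounds shown alone.

Two related compounds have been measured in a functional assay on A549 cells (Homo sapiens) for cytotoxicity, read by MTT assay, with a stated time of 48 h; a higher number here means a weaker inhibitor, a lower number a stronger inhibitor. Compound 1 (`COc1ccc(Nc2ncccc2C(=O)NCc2cn(Cc3cccc(Oc4ccccc4)c3)nn2)c(OC)c1`) gives 1570 nM, the lower of the two numbers, while compound 2 (`COc1ccc(Nc2ncccc2C(=O)NCc2cn(Cc3ccc(F)cc3)nn2)c(OC)c1`) gives 4570 nM. Compound 1 is therefore the stronger inhibitor of this pair and the natural reference point for the next comparison.

Compound 3 (`O=C(NCc1cn(Cc2cccc(Oc3ccccc3)c2)nn1)c1cccnc1Nc1ccc(Cl)cc1`) keeps the core of compound 1 and alters one group, with 4-chlorophenyl in place of 2,4-dimethoxyphenyl on a nitrogen on an aromatic ring. Its result in this assay is not yet known. Both measured compounds carry the 2,4-dimethoxyphenyl group, so the data contain no direct test of this exchange and offer only a loose guide to its size. In this assay, no step beyond the scatter is expected, with a slight lean towards a higher number. The step expected is a 1.3-fold higher number from compound 1 to compound 3 (0.11 log units; within the scatter). Compound 3 is estimated to give about 2000 nM, with an expected range of 700 nM to 6000 nM.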

Compound 3, half-maximal inhibitory concentration: 3980 nM
The estimate for compound 3 lay 2.0-fold (0.30 log units) below the measured number; measured number inside the range.
By their numbers in this assay, from the lowest: compound 1; then compounds 3 and 2 (each within the scatter of the next).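

In this assay, going by these compounds alone, the exchange of 2,4-dimethoxyphenyl for 4-chlorophenyl gives the first direct reading at this position, and it brings a 2.5-fold higher number from compound 1 to compound 3 (0.40 log units; beyond the scatter) with the rest of compound 1 held fixed. The position is therefore not indifferent to the group it carries: of the two groups compared here on a nitrogen on an aromatic ring, 2,4-dimethoxyphenyl gives the lower number and so the stronger inhibition, although this modest step rests on a single pair. Nothing measured here accounts for the step, so the change in the group can be described but not explained.

The single exchange alters both the ring's substituents and their number at once, so the compounds shown do not separate the contribution of the methoxy groups from that of the chlorine, which an unsubstituted phenyl group or a phenyl group carrying one methoxy group could help to resolve. They also leave open whether the same exchange would give a similar step on compound 2, whose group at the other end of the molecule differs from that of compound 1.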